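This account rests on a few compounds, and the source may have more. Where it says the series, first, only, none or still open, it means among the compounds named here.

Measured in a functional assay (muscle tissue) with Rattus norvegicus as the target; a higher number here means that more compound is needed for the effect, a lower number that less compound is needed:
Compound 1 `CCNC(=O)C1=CC(C)(C)Oc2ccc([N+](=O)[O-])cc21`: 4.57 nM
Compound 2 `CC1(C)C=C(C(=O)NC2CC2)c2cc([N+](=O)[O-])ccc2O1`: 32.4 nM

Of these two, compound 2 holds the higher number, at 32.4 nM, so more of it is needed for the effect. The change now in question leads to compound 3 `C#CCNC(=O)C1=CC(C)(C)Oc2ccc([N+](=O)[O-])cc21`, which keeps the shared core and puts propargyl in place of cyclopropyl on an amide-type nitrogen.

Among the measured compounds shown here, only one measured step bears on this change. In a 7.1-fold higher number from compound 1 to compound 2 (0.85 log units; beyond the scatter), cyclopropyl took the place of ethyl at the same nitrogen, and that step is modest in size. Propargyl, like ethyl, has no ring, so a step to a lower number in this assay is expected on leaving compound 2. For the measured compounds named here, this rests on compound 1 alone, at 4.57 nM, and no propargyl compound has yet been measured, so the expected step is smaller than the measured one and remains uncertain. The step expected is a 2.3-fold lower number from compound 2 to compound 3 (0.36 log units; beyond the scatter). For compound 3 the estimated value is 14 nM, with an expected range of 4 nM to 50 nM.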

Compound 3, half-maximal effective concentration: 7.94 nM
Compound 3: middle estimate off by 1.8-fold (0.25 log units), on the high side, and the stated range covers the measured number.
By their numbers in this assay, from the lowest: compounds 1 and 3 (each within the scatter of the next); then compound 2.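

In this assay, among the compounds shown here, the earlier compounds showed only that cyclopropyl on this amide-type nitrogen gave a higher number than ethyl, and the step of a 4.1-fold lower number from compound 2 to compound 3 (0.61 log units; beyond the scatter) now shows that a second group without a ring, propargyl, also stands clear of cyclopropyl even though both carry 3 heavy atoms. Across these three compounds the two open chains therefore stay together, with a 1.7-fold higher number from compound 1 to compound 3 (0.24 log units; within the scatter) keeping ethyl and propargyl inside the scatter, so exchanging a methyl end for an ethynyl end on the chain leaves no readable difference in this assay, and only the ring-bearing compound 2 stands apart. The compounds come with no supporting data that could give a reason for this separation.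

The compounds shown leave open whether the higher number of compound 2 belongs to cyclopropyl alone or to rings on this nitrogen in general, a question that a cyclobutyl group would address. They also leave open how far an open chain can grow at this nitrogen before the number changes, as a longer chain such as n-butyl would show.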